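Adding a Methoxy Group to Compound 3

A few compounds are considered here, and "the series" means these few. Any claim that something is new, unique, unknown or untested is made for them only; others in the source may bear on it.

Compound 3 `Cn1c(N2N=C(c3ccc(Cl)cc3)CC2c2ccccc2)nc(-c2ccc(Cl)cc2)c(C#N)c1=O` gives 25300 nM in a functional assay on MCF7 cells (Homo sapiens) for antiproliferative activity, with a stated time of 72 h (a higher number here means a weaker inhibitor, a lower number a stronger inhibitor), the second highest of the three values. Compound 2 `COc1ccc(C2CC(c3ccccc3)=NN2c2nc(-c3ccc(Cl)cc3)c(C#N)c(=O)n2C)cc1` stands nearest with 52400 nM, beyond the scatter, while compound 1 `COc1ccc(C2CC(c3ccc(Cl)cc3)=NN2c2nc(-c3ccccc3)c(C#N)c(=O)n2C)cc1` lies furthest with 4800 nM. The change to compound 4 `COc1ccc(C2CC(c3ccc(Cl)cc3)=NN2c2nc(-c3ccc(Cl)cc3)c(C#N)c(=O)n2C)cc1` is methoxy in place of hydrogen on an aromatic carbon, on an aromatic carbon of a six-membered aromatic ring of carbon only, para to a large group. Among the measured compounds shown here, no measured pair shows this change alone, so its size is not known. Compound 3 is expected to move from compound 3 to compound 4 by a 1.7-fold lower number from compound 3 to compound 4 (0.23 log units; within the scatter), a modest step downward. Compound 4 is estimated at 15000 nM, between 4000 nM and 50000 nM.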

Compound 4, half-maximal inhibitory concentration: 27300 nM
Compound 4: middle estimate off by 1.8-fold (0.26 log units), on the low side, within the range that was stated.
By their numbers in this assay, from the lowest: compound 1; then compounds 3, 4 and 2 (each within the scatter of the next, the first and the last beyond it).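

With a 1.1-fold higher number from compound 3 to compound 4 (0.03 log units; within the scatter) as its whole effect, phenyl to 4-methoxyphenyl leaves this assay without a readable change when both chloro groups are present. Chloro in place of hydrogen depends on its place, with a 1.9-fold lower number from compound 2 to compound 4 (0.28 log units; within the scatter) staying within the scatter and a 5.7-fold higher number from compound 1 to compound 4 (0.75 log units; beyond the scatter) going beyond it. No evidence is available to explain this difference.

As far as these compounds go, whether an amine or a hydroxyl group at this position would read differently from methoxy remains open. So does whether methoxy would give the same result in a compound without the chloro groups.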